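The source may report more compounds than this note shows. Statements on the series, on what has been measured and on what is new or still open speak of the compounds shown alone.

Measured so far in an assay on CCRF-CEM cells for displacement of a labelled ligand from C-C chemokine receptor type 4 (Homo sapiens); on this read-out higher numbers stand for weaker inhibition and lower numbers for stronger inhibition:
compound 1, `CC(C)(C)c1csc(Nc2ccccc2)n1`: 4500 nM
compound 2, `Cc1ccccc1Nc1nc(C(C)(C)C)cs1`: 900 nM

Going by the values given here, compound 2 holds the lower of the two numbers; the only measured step in the set is a 5.0-fold lower number from compound 1 to compound 2 (0.70 log units; beyond the scatter), which came with methyl in place of hydrogen on an aromatic carbon. That is the whole precedent.

Compound 3, `Cc1cccc(Nc2nc(C(C)(C)C)cs2)c1C`, continues in the same direction: methyl in place of hydrogen on an aromatic carbon. Among the compounds with values here, the one step that bears on it is the methyl addition above, a modest gain beyond the scatter. It need not carry over, since the new methyl enters at a place described only as ortho to a methyl group and meta to a large group, and nothing measured speaks to a second methyl on that ring. The working expectation is therefore a small step in the same direction, one that may well sit within the scatter, rather than a repeat of the earlier gain. For compound 3 in this assay the estimate is 600 nM, with a range of 200 nM to 2000 nM, which amounts to an expected 1.5-fold lower number from compound 2 to compound 3 (0.18 log units; within the scatter).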

Compound 3, half-maximal inhibitory concentration: 260 nM
Compound 3: middle estimate off by 2.3-fold (0.36 log units), on the high side; the measured number falls inside the stated range.
By their numbers in this assay, from the lowest: compound 3; then compound 2; then compound 1.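

In this assay the ring now carries a second methyl and the number keeps falling: the new methyl, ortho to a methyl group and meta to a large group, gives a 3.5-fold lower number from compound 2 to compound 3 (0.54 log units; beyond the scatter) and so adds a further gain to the first one. Going by these compounds alone, the earlier compounds showed only a single methyl on this ring, with a 5.0-fold lower number from compound 1 to compound 2 (0.70 log units; beyond the scatter) and nothing beyond it, so this result is the first sign that the ring can take more than one methyl with the number still moving down. Both steps are modest and beyond the scatter, and they run the same way across compound 1, compound 2 and compound 3, with none of the three going against the trend. No evidence in hand explains the lower number seen with the added methyl.

Still open, on these data alone, is whether the gain at this place belongs to methyl itself or would also come with a longer chain such as ethyl, with methoxy, with chlorine or with an amine. Also open, as far as these compounds go, is whether the new methyl would give a similar step on the ring without the first methyl, and whether a third methyl would extend the trend.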